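Cyclopropylmethyl and alkenyl substituents on a bromoaryl imidazoline series

A few compounds are considered here, and "the series" means these few. Any claim that something is new, unique, unknown or untested is made for them only; others in the source may bear on it.

Measured compounds:
- compound 1, `Brc1ccc(N(CC2CC2)C2=NCCN2)c(Br)c1`, -0.31
- compound 2, `Brc1cccc(N(CC2CC2)C2=NCCN2)c1Br`, -0.41
- compound 3, `C/C=C/CN(C1=NCCN1)c1c(Br)cccc1Br`, -0.49

All three values come from a physicochemical assay for lipophilicity; on this read-out higher numbers stand for higher lipophilicity and lower numbers for lower lipophilicity. In this assay compound 3 gives -0.49, and the gaps to compound 2 and to compound 1 both sit within the usual scatter, so the three compounds form one narrow band and no order among them can be read from these numbers.

Compound 4, `Brc1cccc(Br)c1N(C1=NCCN1)C1CCCCC1`, has not yet been measured. It differs from compound 3 in one place: cyclohexyl in place of but-2-en-1-yl on a nitrogen on an aromatic ring. Going by the values given here, no two measured compounds differ in one place, so there is no measured step to lean on; the expectation for compound 4 rests only on the value of compound 3 and the nature of the change. A step upward, beyond the scatter, is expected from compound 3 to compound 4 , namely a number 0.79 log units higher from compound 3 to compound 4 (beyond the scatter). Compound 4 is therefore estimated at 0.3, with a range from -0.2 to 0.8.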

Compound 4, distribution coefficient: 0.14
The estimate for compound 4 lay 0.16 log units above the measured number; measured number inside the range.
By their numbers in this assay, from the lowest: compounds 3, 2 and 1 (each within the scatter of the next); then compound 4.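

Going by these compounds alone, on the nitrogen on an aromatic ring, cyclohexyl in place of but-2-en-1-yl gives a modest rise in this assay, a number 0.63 log units higher from compound 3 to compound 4 (beyond the scatter), the only single-place step so far and one that lies beyond the scatter. Within the data shown here, with the rest of the structure unchanged, this shows that the group at this position alone can move the number out of the narrow band formed by the earlier compounds. Nothing at hand accounts for the size of this step.

This one step does not separate the presence of the ring from the change in carbon count or the loss of the double bond, and a saturated butyl chain or a cyclobutyl group at the same place would bear on that. Also open, going by these compounds, is how a cyclohexyl group carrying a hydroxyl or an amine would read.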